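Working notes: replacing the 1H-indol-3-yl group of compound 2

A few compounds are considered here, and "the series" means these few. Any claim that something is new, unique, unknown or untested is made for them only; others in the source may bear on it.

Compound 1 `CC(C)N(Cc1cccc(OCCCCCC(=O)O)c1)C(=O)c1ccc(-c2cccc(OCc3ccccc3)c2)cc1` | > 26000 nM | a limit
Compound 2 `CC(C)N(Cc1cccc(OCCCCCC(=O)O)c1)C(=O)c1ccc(-c2c[nH]c3ccccc23)cc1` | > 26000 nM | a limit

In an ADME assay on HEK293 cells (Homo sapiens) for cytotoxicity, read by CellTiter-Glo and resazurin assay, with a stated time of 72 h (a higher number here means that more compound is needed for the effect, a lower number that less compound is needed), compound 2 gives > 26000 nM as a limit and not a number. Compound 1 likewise gives only a limit (> 26000 nM) with a different group in that place. Compound 3 `CC(C)N(Cc1cccc(OCCCCCC(=O)O)c1)C(=O)c1ccc(-c2cccc(F)c2)cc1` carries 3-fluorophenyl in place of 1H-indol-3-yl on an aromatic carbon. Going by the values given here, no measured step is available, and the only guide is the limit of > 26000 nM in this assay, at which 2 of the 2 values shown sit. In this assay no step beyond the scatter, in either direction, is expected. The expected step that the limit leaves unreadable from compound 2 to compound 3 stays within that scatter. For compound 3 the estimated value is 30000 nM (expected range 14000 nM to 60000 nM), most likely reported as a limit again.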

Compound 3, half-maximal effective concentration: > 26000 nM
Compound 3 gave a limit, no number; the forecaster's own chance of this, stated with the estimate: 85%; the middle value lies beyond the limit too.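

In this assay, going by these compounds alone, compound 1, compound 2 and compound 3 all stand as limits and not numbers, so no step between them can be read. The compounds shown leave open whether any group in this place would give a number instead of a limit: the limit of > 26000 nM in this assay, at which 3 of the 3 values shown sit.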